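The compounds below may be only part of what the source reports. "The series", "measured", "known", "first", "only" and "open" are said of these compounds alone.

Going by the values given here, in a functional assay on K562 cells (Homo sapiens) for cytotoxicity, read by trypan blue exclusion, with a stated time of 96 h (on this read-out lower numbers stand for stronger inhibition and higher numbers for weaker inhibition), compound 1 `COC(=O)C(Nc1cc(CS(=O)(=O)/C=C/c2c(OC)cc(OC)cc2OC)ccc1OC)c1ccccc1` gives 30 nM and compound 2 `COC(=O)C(Nc1cc(CS(=O)(=O)/C=C/c2c(OC)cc(OC)cc2OC)ccc1OC)c1ccc(OC)cc1` gives 150 nM, which leaves compound 1 with the lower of the two numbers known so far. Compound 3 `COc1cc(OC)c(/C=C/S(=O)(=O)Cc2ccc(OC)c(NC(F)(F)C(=O)O)c2)c(OC)c1` has not yet been measured. It differs from compound 1 as follows: carboxy(difluoro)methyl in place of methoxycarbonyl)(benzyl on a nitrogen on an aromatic ring. Among the compounds with values here, only one measured step bears on this change, and only indirectly: a 5.0-fold higher number from compound 1 to compound 2 (0.70 log units; beyond the scatter), with methoxy in place of hydrogen on an aromatic carbon. This step is modest but beyond the scatter, and it falls within the group that leaves in compound 3. Within the data shown here, no measured step shows what removing that group does, or what carboxy(difluoro)methyl does on that nitrogen. Since that one small alteration took compound 2 to 150 nM, a far larger replacement is expected to raise the number in this assay as well, by a step of similar size or somewhat more. The expected step is a 4.0-fold higher number from compound 1 to compound 3 (0.60 log units; beyond the scatter), and it is uncertain. For compound 3 the estimated value is 120 nM, with an expected range from 25 nM to 700 nM.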

Compound 3, half-maximal inhibitory concentration: 150 nM
Compound 3: middle estimate off by 1.3-fold (0.10 log units), on the low side; the measured number falls inside the stated range.
By their numbers in this assay, from the lowest: compound 1; then compounds 2 and 3 (each within the scatter of the next).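

In this assay, going by these compounds alone, the change on a nitrogen on an aromatic ring gives a 5.0-fold higher number from compound 1 to compound 3 (0.70 log units; beyond the scatter), so this nitrogen tolerates more than the single methoxy step on the leaving group had suggested: the whole methoxycarbonyl)(benzyl group can go, with its six-membered aromatic ring, and the number moves only modestly. Compound 3 carries carboxy(difluoro)methyl on that nitrogen, with no ring there and fewer heavy atoms, and still gives 150 nM, so an aromatic ring in this place is not needed for activity at this level, although the step is beyond the scatter and compound 1 keeps the lower number. Nothing measured here explains why the number rises with this change.

The single replacement alters the ring, the ester and the fluorine content all at once, so the compounds shown leave open which of these parts accounts for the step. A carboxymethyl group without the fluorine atoms, or the methyl ester of the difluoro acid, on the same nitrogen would begin to separate those contributions.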